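The compounds below may be only part of what the source reports. "The series", "measured", "known", "first", "only" and "open" are said of these compounds alone.

In a functional assay on the whole organism for antagonist activity, with Mus musculus as the target, in the maximal electroshock model (a higher number here means that more compound is needed for the effect, a lower number that less compound is needed), compound 3 `Cn1c(-c2ccccc2)nnc1S(C)(=O)=O` reads > 200 mg/kg, which is a limit and not a number. Compound 1 `Cn1c(-c2cccc(F)c2)nnc1S(C)(=O)=O` gives > 200 mg/kg, also a limit. Compound 2 `CSc1nnc(-c2ccc(F)cc2)n1C` gives > 200 mg/kg, again a limit. Compound 4 `CC[S+]([O-])c1nnc(-c2ccccc2)n1C` departs from compound 3 by a group of 4 heavy atoms (2 carbon, 1 oxygen, 1 sulfur; no ring) in place of a group of 4 heavy atoms (1 carbon, 2 oxygen, 1 sulfur; no ring), on an aromatic carbon. Among the measured compounds shown here, the one measured step, a step that the two limits leave unreadable from compound 1 to compound 3, swaps hydrogen for fluoro elsewhere and does not touch this group, so the only guide is the limit of > 200 mg/kg in this assay, at which 3 of the 3 values shown sit. For the measured compounds named here, no step of readable size can be derived for this change, and no shift in either direction is foreseen. The expected step is a step that the limit leaves unreadable from compound 3 to compound 4. Compound 4 is estimated at 250 mg/kg, with an expected range from 120 mg/kg to 500 mg/kg.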

Compound 4, dose for half-maximal effect: > 200 mg/kg
Compound 4 ended at the assay's limit; the forecaster's own chance of this, stated with the estimate: 75%; the middle value does not contradict the limit.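

No step can be read between compound 3 and compound 4 in this assay: both values are limits. The compounds shown leave open whether replacing the methylsulfonyl group shifts the dose needed at all.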